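The source may hold more compounds than are shown below. What is called first, only, known or untested is meant among the compounds shown, and "the series" means these compounds.

Measured so far:
- compound 1, `COc1cc(-c2cc(/C=C/C(=O)c3ccc(Cl)c(Cl)c3)[nH]n2)cc(OC)c1OC`: 97%
- compound 2, `COc1ccc(-c2cc(/C=C/C(=O)c3ccc(N)cc3)[nH]n2)cc1OC`: 106%

In a functional assay on IGROV-1 cells (Homo sapiens) for cytotoxicity, read by sulforhodamine B assay, with a stated time of 48 h, tested at 0.01 uM (on this read-out lower numbers stand for a stronger effect and higher numbers for a weaker effect at the one concentration tested), compound 1 gives 97% and compound 2 gives 106%. Compound 1 has the lower of the two numbers, but compound 2 lies within the usual scatter of it, so the two cannot be told apart, and both sit near the level at which no effect is seen at the single concentration tested.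

Compound 3, `COc1cc(-c2cc(/C=C/C(=O)c3ccc(F)c(F)c3)[nH]n2)cc(OC)c1OC`, is not yet measured. It differs from compound 1 at one place only: 3,4-difluorophenyl in place of 3,4-dichlorophenyl on a carbonyl carbon. Both fluorine atoms of the entering group replace chlorine atoms of the leaving group, the ring and the carbonyl attachment staying the same.

Among the measured compounds shown here, no step between measured compounds is available as a guide. On the two numbers in hand, nothing beyond the scatter is expected in this assay from compound 1 to compound 3, in either direction. Compound 3 is expected to give 99%, between 88% and 110%. The step of a number 2 percentage points higher from compound 1 to compound 3 (within the scatter) is thus estimated to stay within the scatter.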

Compound 3, a percentage reported as activity, at one concentration (the size of the read-out at that concentration, not a potency): 97%
Estimate against measurement, compound 3: 2 percentage points above; low and high end bracket the measured number.
By their numbers in this assay, from the lowest: compounds 1, 3 and 2 (each within the scatter of the next).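

In this assay, among the compounds shown here, the exchange of 3,4-dichlorophenyl for 3,4-difluorophenyl on a carbonyl carbon gives no change at the digits printed from compound 1 to compound 3 (within the scatter) and provides the first single-place step. At this one concentration, the read-out therefore does not separate these two halogen pairs on the phenyl ring, though compound 1 and compound 3 both sit near the no-effect level, so the step says little about how the position would behave where an effect is seen. Nothing at hand bears on why the two read alike.

Open, as far as these compounds go, is whether a carboxylic acid or a morpholine on that phenyl ring would move the read-out beyond the scatter. Also open, from the compounds shown here alone, is whether compound 1 and compound 3 would still read alike at higher concentrations, where an effect might appear.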